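From pyridin-4-yl to pyridin-3-yl in compound 4

A few compounds are considered here, and "the series" means these few. Any claim that something is new, unique, unknown or untested is made for them only; others in the source may bear on it.

Measured so far in a functional assay on PANC-1 cells (Homo sapiens) for antiproliferative activity, read by fluorescence and resazurin assay, with a stated time of 48 h; a higher number here means a weaker inhibitor, a lower number a stronger inhibitor:
- compound 1 `O=C(N/N=C/c1ccncc1)c1cc2cc(Br)ccc2oc1=O` gives 25700 nM
- compound 2 `O=C(N/N=C/c1ccncc1)c1cc2cc([N+](=O)[O-])ccc2oc1=O` gives 26100 nM
- compound 3 `O=C(N/N=C/c1ccncc1)c1cc2ccccc2oc1=O` gives 9750 nM

Compound 1 stands at the high end of these three numbers, a weak position in this assay. Its nearest step is a 1.0-fold higher number from compound 1 to compound 2 (0.01 log units; within the scatter), and its furthest is a 2.6-fold lower number from compound 1 to compound 3 (0.42 log units; beyond the scatter).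

Compound 4 `O=C(N/N=C/c1cccnc1)c1cc2cc(Br)ccc2oc1=O` keeps the core of compound 1 and swaps one group: pyridin-3-yl in place of pyridin-4-yl on a carbon with a double bond to nitrogen. This puts pyridin-3-yl in place of pyridin-4-yl on a carbon with a double bond to nitrogen.

Within the data shown here, no measured step changes this group. The measured steps elsewhere on the core stay modest, such as a 2.7-fold lower number from compound 2 to compound 3 (0.43 log units; beyond the scatter), so they give only a rough sense of scale. No step beyond the scatter is therefore expected, and no direction can be argued. The estimated step is a 1.1-fold lower number from compound 1 to compound 4 (0.03 log units; within the scatter).

For compound 4 the expected value is 24000 nM, with an estimated range from 10000 nM to 55000 nM.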

Compound 4, half-maximal inhibitory concentration: 8350 nM
Estimate against measurement, compound 4: 2.9-fold (0.46 log units) above; the measured number lies below the stated range.
By their numbers in this assay, from the lowest: compounds 4 and 3 (each within the scatter of the next); then compounds 1 and 2 (each within the scatter of the next).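

The step at this place, a 3.1-fold lower number from compound 1 to compound 4 (0.49 log units; beyond the scatter), is the first one shown away from the bromo-bearing side of the core, and it lies beyond the scatter although modest. Both groups have the same atoms and counts, so in this assay the way the pyridine ring is joined alone separates compound 1 from compound 4. Nothing available explains this difference.

From the compounds shown here alone, whether pyridin-3-yl gives a similar step alongside the nitro of compound 2 or the hydrogen of compound 3 remains open. So does the effect of a pyridin-2-yl or plain phenyl ring at this place.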